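Replacing 3-fluorophenyl with 6-fluoropyridin-3-yl on a shared core

A few compounds are considered here, and "the series" means these few. Any claim that something is new, unique, unknown or untested is made for them only; others in the source may bear on it.

Three compounds have been measured in a functional assay on A549 cells (Homo sapiens) for antiproliferative activity, read by sulforhodamine B assay, with a stated time of 48 h; on this read-out lower numbers stand for stronger inhibition and higher numbers for weaker inhibition:
- Compound 1 `COc1ccc(/C=C/C(=O)c2ccccc2-c2ccc(OC)c(OC)c2)cc1OC`: 8500 nM
- Compound 2 `COc1ccc(/C=C/C(=O)c2ccccc2-c2ccc(F)cc2)cc1OC`: 440 nM
- Compound 3 `COc1ccc(/C=C/C(=O)c2ccccc2-c2cccc(F)c2)cc1OC`: 330 nM

Two of the three share the low end of the numbers, separated by a 1.3-fold lower number from compound 2 to compound 3 (0.12 log units; within the scatter). The remaining compound lies far off, as shown by a 26-fold lower number from compound 1 to compound 3 (1.41 log units; beyond the scatter). Compound 3 therefore stands with its closest neighbour well clear of the dimethoxy-substituted member.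

The next compound is compound 4 `COc1ccc(/C=C/C(=O)c2ccccc2-c2ccc(F)nc2)cc1OC`, and the change is 6-fluoropyridin-3-yl in place of 3-fluorophenyl on an aromatic carbon. In words, 6-fluoropyridin-3-yl stands in place of 3-fluorophenyl on an aromatic carbon, ortho to a large group.

Two kinds of measured step bear on this change. The large ones, a 19-fold lower number from compound 1 to compound 2 (1.29 log units; beyond the scatter) and a 26-fold lower number from compound 1 to compound 3 (1.41 log units; beyond the scatter), remove the 3,4-dimethoxyphenyl group, which stays absent here, so they say little about compound 4. Closer is the exchange between the two fluorophenyl groups, a 1.3-fold lower number from compound 2 to compound 3 (0.12 log units; within the scatter), which suggests that this part of the molecule tolerates a modest edit. For the measured compounds named here, none of the measured steps puts a nitrogen into this aromatic ring, so the direction remains uncertain, and only a small loss is expected. The expected change is a 1.5-fold higher number from compound 3 to compound 4 (0.18 log units; within the scatter). For compound 4 the estimated value is 500 nM, with an expected range from 160 nM to 1600 nM.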

Compound 4, half-maximal inhibitory concentration: 1200 nM
Beside the measured number, compound 4's estimate is 2.4-fold (0.38 log units) below it; the range from low to high includes it.
By their numbers in this assay, from the lowest: compounds 3 and 2 (each within the scatter of the next); then compound 4; then compound 1.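

In this assay, this position, on an aromatic carbon ortho to a large group, proved sensitive to a change in the ring itself, although moving the fluorine between the two fluorophenyl groups had stayed within the scatter, at a 1.3-fold lower number from compound 2 to compound 3 (0.12 log units; within the scatter). Exchanging a ring of carbon only for 6-fluoropyridin-3-yl, which adds a hydrogen-bond acceptor by count, gave a 3.6-fold higher number from compound 3 to compound 4 (0.56 log units; beyond the scatter) and a 2.7-fold higher number from compound 2 to compound 4 (0.44 log units; beyond the scatter), both beyond the scatter, so the tolerance suggested by the fluorophenyl pair did not extend to this edit. The pyridine still kept much of the advantage over the 3,4-dimethoxyphenyl group, with a 7.1-fold lower number from compound 1 to compound 4 (0.85 log units; beyond the scatter), placing it on an intermediate rung rather than at either end of the series.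

Nothing available explains why this exchange raises the number.

The compounds shown leave open whether the same step would appear with an unsubstituted pyridin-3-yl group, or with an amine or a methoxy group in place of the fluorine on the pyridine. They also leave open how a pyrimidine ring or a nitrogen elsewhere in this ring would compare.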